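The compounds below may be only part of what the source reports. "The series", "measured", "known", "first", "only" and "open" are said of these compounds alone.

Measured so far:
compound 1 `Cc1cn([C@@H]2O[C@H](CO[Si](C)(C)C(C)(C)C)[C@@]3(OS(=O)(=O)C=C3NCC(=O)O)[C@H]2O[Si](C)(C)C(C)(C)C)c(=O)n(C)c1=O`: 300000 nM
compound 2 `C=C(C)C(=O)NC(=O)NC1=CS(=O)(=O)O[C@@]12[C@@H](CO[Si](C)(C)C(C)(C)C)O[C@@H](n1cc(C)c(=O)n(C)c1=O)[C@@H]2O[Si](C)(C)C(C)(C)C`: 20000 nM

In a functional assay on HEL cells (Homo sapiens) for cytotoxicity, read by microscopy (on this read-out higher numbers stand for lower toxicity in this test and lower numbers for higher toxicity in this test), compound 1 holds the highest number of the two, with compound 2 the nearest. Compound 3 `Cc1cn([C@@H]2O[C@H](CO[Si](C)(C)C(C)(C)C)[C@@]3(OS(=O)(=O)C=C3NC(=O)NC(=O)c3ccccc3)[C@H]2O[Si](C)(C)C(C)(C)C)c(=O)n(C)c1=O` differs from compound 1 by benzoylcarbamoyl in place of carboxymethyl on an amine nitrogen. Within the data shown here, the one measured step bearing on this is a 15-fold lower number from compound 1 to compound 2 (1.18 log units; beyond the scatter), where ((1-methylethenyl)carbonyl)carbamoyl likewise entered for carboxymethyl on an amine nitrogen, a large move. A step of similar direction is therefore expected for compound 3, estimated as a 10-fold lower number from compound 1 to compound 3 (1.00 log units; beyond the scatter). Compound 3 is expected to give 30000 nM, with a range of 8000 nM to 120000 nM.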

Compound 3, minimum cytotoxic concentration: >= 80000 nM
Compound 3 ended at the assay's limit (the forecaster's own chance of this, stated with the estimate: 10%); middle value at least 2.6-fold (0.42 log units) from the limit.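

In this assay, compound 3 gives >= 80000 nM, which is a limit of the assay and not a number. The step from the carboxymethyl compound cannot be read because compound 3 ends at that limit: the limit of >= 80000 nM in this assay, at which 1 of the 3 values shown sits. Between the two carbamoyl compounds, phenyl in place of 1-methylethenyl on a carbonyl carbon gives an at least 4.0-fold higher number from compound 2 to compound 3 (0.60 log units; beyond the scatter), so the read-out depends on that carbonyl substituent, not on the carbamoyl group alone.

From the compounds shown here alone, whether compound 3 lies level with compound 1 remains open. So does the reading in this assay with a saturated alkyl chain or a pyridine ring on that carbonyl carbon.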